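Varying the amine cap on the shared core

The source may report more compounds than this note shows. Statements on the series, on what has been measured and on what is new or still open speak of the compounds shown alone.

Measured compounds and values:
compound 1 `CCN(CC)CCN1CCN(C(=O)COCCN(C)S(=O)(=O)c2c(C)cc(OC)cc2C)CC1`: 7.8
compound 2 `COc1cc(C)c(S(=O)(=O)N(C)CCOCC(=O)N2CCN(C3CCN(C4CC4)CC3)CC2)c(C)c1`: 8.5

Of the compounds shown here, two have been measured in a functional assay on Umbilical vein for antagonist activity at B1 bradykinin receptor (Homo sapiens), using Schild analysis, with a stated time of 30 min; a lower number here means a less potent compound, a higher number a more potent compound, by a factor of ten per unit of this negative logarithm. Compound 1 gives 7.8 and compound 2 gives 8.5 in this assay. Within the data shown here, compound 2 thus stands highest of the two numbers; its only neighbour is compound 1, and the step of a number 0.70 log units higher from compound 1 to compound 2 (beyond the scatter) lies beyond the scatter. Among the measured compounds shown here, that step replaced 2-(diethylamino)ethyl with 1-cyclopropylpiperidin-4-yl on the amine nitrogen in the ring, and it is the only measured step that touches this position.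

Compound 3 `COc1cc(C)c(S(=O)(=O)N(C)CCOCC(=O)N2CCN([C@@H]3CN4CCC3CC4)CC2)c(C)c1` is the next variant at the same position: a group of 8 heavy atoms (7 carbon, 1 nitrogen; 2 six-membered non-aromatic rings with 1 hetero atom each) in place of a group of 9 heavy atoms (8 carbon, 1 nitrogen; one three-membered non-aromatic ring of carbon only, one six-membered non-aromatic ring with 1 hetero atom), on an amine nitrogen in a ring. Both the leaving and the entering group hold one nitrogen and one hydrogen-bond acceptor, carry no net charge, and differ by a single heavy atom; the entering group is made of two six-membered non-aromatic rings instead of a three-membered and a six-membered ring. For the measured compounds named here, only the step from compound 1 to compound 2 bears on this change, and it was a number 0.70 log units higher from compound 1 to compound 2 (beyond the scatter); nothing measured distinguishes one ring amine from another. For compound 3 the expected step in this assay is therefore small, a number 0.10 log units lower from compound 2 to compound 3 (within the scatter). Compound 3 is estimated at 8.4, with a range from 7.8 to 9.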

Compound 3, negative logarithm of the antagonist equilibrium constant: 8.1
Compound 3: the middle estimate sits 0.30 log units above what was measured, within the range that was stated.
By their numbers in this assay, from the lowest: compounds 1 and 3 (each within the scatter of the next); then compound 2.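

Ring amines at this position are not interchangeable in this assay: the group with two six-membered non-aromatic rings, in place of 1-cyclopropylpiperidin-4-yl, gives a number 0.40 log units lower from compound 2 to compound 3 (beyond the scatter), so the position separates one ring amine from another, which the first pair could not show. Rings on this nitrogen do not by themselves reach the level of compound 2, and compound 3 goes against any such reading: with the same group in place of the open-chain 2-(diethylamino)ethyl, the series shows a number 0.30 log units higher from compound 1 to compound 3 (within the scatter), leaving these two groups unresolved from each other. Nothing at hand accounts for the difference between the two ring amines.

The compounds shown leave open how much of the level of compound 2 rests on the cyclopropyl group and how much on the piperidine ring, a question that a 1-methylpiperidin-4-yl or 1-isopropylpiperidin-4-yl group on the same nitrogen would address. Also open, on these data alone, is what the opposite configuration at the defined stereocentre of the entering group would give in this assay.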